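Moving the Bromine on a Thiophene Sulfonamide

The compounds below may be only part of what the source reports. "The series", "measured", "known", "first", "only" and "open" are said of these compounds alone.

Of the compounds shown here, two have been measured in a functional assay on HepG2 cells for inhibition of squalene monooxygenase (Homo sapiens); a higher number here means a weaker inhibitor, a lower number a stronger inhibitor. Compound 1 `CCN(C/C=C/C#CC(C)(C)C)Cc1cccc(OCCN(C)S(=O)(=O)c2ccc(Br)cc2)c1` gives 330 nM in this assay. Compound 2 `CCN(C/C=C/C#CC(C)(C)C)Cc1cccc(OCCN(C)S(=O)(=O)c2ccc(Br)s2)c1` carries a 5-bromothiophen-2-yl group on the sulfonyl sulfur instead of the 4-bromophenyl group of compound 1. In this assay compound 2 gives 390 nM. That exchange produced a 1.2-fold higher number from compound 1 to compound 2 (0.07 log units; within the scatter), so the two values cannot be told apart. Compound 2 therefore holds the higher of the two numbers, but only within the scatter of the measurement.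

Compound 3 `CCN(C/C=C/C#CC(C)(C)C)Cc1cccc(OCCN(C)S(=O)(=O)c2cc(Br)cs2)c1` is the unmeasured partner. It differs from compound 2 in one respect: 4-bromothiophen-2-yl in place of 5-bromothiophen-2-yl on a sulfonyl sulfur. For the measured compounds named here, the only measured step, from the phenyl to the thiophene, lay within the scatter and does not speak directly to shifting the bromine within the thiophene ring. Going by the values given here, no step among the measured compounds shows how such a shift acts. The expectation is therefore a step of a 1.1-fold higher number from compound 2 to compound 3 (0.03 log units; within the scatter) in this assay, that is, nothing beyond the scatter. Compound 3 is expected to give about 420 nM in this assay, with a range from 180 nM to 1000 nM.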

Compound 3, half-maximal inhibitory concentration: 300 nM
The estimate for compound 3 lay 1.4-fold (0.15 log units) above the measured number; the range from low to high includes it.
By their numbers in this assay, from the lowest: compounds 3, 1 and 2 (each within the scatter of the next).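

For the compounds shown here, exchanging the 5-bromothiophen-2-yl group on the sulfonyl sulfur for the 4-bromothiophen-2-yl group gives a 1.3-fold lower number from compound 2 to compound 3 (0.11 log units; within the scatter) in this assay, the first direct reading of what moving the bromine within the thiophene ring does here. Set against the 4-bromophenyl group of compound 1, the same 4-bromothiophen-2-yl group gives a 1.1-fold lower number from compound 1 to compound 3 (0.04 log units; within the scatter), so all three bromine-bearing rings tried on the sulfonyl sulfur, in compound 1, compound 2 and compound 3, cannot be told apart in this assay, and neither the choice of ring nor the place of the bromine on the thiophene shows any measurable effect among these three compounds. No evidence is at hand on what lies behind these closely matched numbers.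

All three compounds carry a bromine, so the compounds shown leave open whether this atom matters at all, a question that a thiophene bearing chlorine, a methyl group or a nitrile in its place could address. They also leave open how a larger change on the sulfonyl sulfur, such as a ring carrying a carboxylic acid or an amine, would read in this assay.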